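The source may hold more compounds than are shown below. What is called first, only, known or untested is meant among the compounds shown, and "the series" means these compounds.

In a functional assay on WM1361 cells (Homo sapiens) for inhibition, read by MTT assay, with a stated time of 24 h (on this read-out higher numbers stand for weaker inhibition and lower numbers for stronger inhibition), compound 1 `O=c1oc2ccccc2c(N2CCN(c3ccccc3F)CC2)c1CO` reads > 50000 nM, which is a limit of the assay and not a number. Within the data shown here, compound 2 `COc1ccc(N2CCN(c3c(CO)c(=O)oc4ccccc34)CC2)cc1` gives 40400 nM, the only actual number so far. Compound 3 `O=c1oc2ccccc2c(N2CCN(c3cccc(Cl)c3)CC2)c1CO` departs from compound 2 by 3-chlorophenyl in place of 4-methoxyphenyl on an amine nitrogen in a ring, placing 3-chlorophenyl where 4-methoxyphenyl stood on an amine nitrogen in a ring. Among the measured compounds shown here, the one measured step at that place, 4-methoxyphenyl in place of 2-fluorophenyl, is an at least 1.2-fold lower number from compound 1 to compound 2 (0.09 log units; that floor lies within the scatter), so no change beyond the scatter is expected in this assay. The estimated 1.2-fold lower number from compound 2 to compound 3 (0.06 log units; within the scatter) is expected to stay within that scatter. Compound 3 is expected at 35000 nM, with an estimated range of 15000 nM to 70000 nM.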

Compound 3, half-maximal inhibitory concentration: > 50000 nM
Compound 3: only a limit was reported; the forecaster's own chance of this, stated with the estimate: 35%; at least 1.4-fold (0.15 log units) between middle value and limit.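

In this assay compound 3 reads > 50000 nM, which is a limit of the assay and not a number. Placing 3-chlorophenyl on the amine nitrogen gives an at least 1.2-fold higher number from compound 2 to compound 3 (0.09 log units; that floor lies within the scatter), so a chlorine-bearing phenyl now joins the fluorine- and methoxy-bearing ones at this position without any readable step beyond the scatter. The step from compound 1 to compound 3 cannot be read, and the comparison stays narrow: the limit of > 50000 nM in this assay, at which 2 of the 3 values shown sit. From the compounds shown here alone, whether an amine or a carboxylic acid on the phenyl ring, or a cyclohexyl group in its place, would read clearly lower remains open.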